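A few compounds are considered here, and "the series" means these few. Any claim that something is new, unique, unknown or untested is made for them only; others in the source may bear on it.

Measured compounds:
- compound 1, `O=[N+]([O-])c1ccc2nc(O)c(-c3ccccc3)c(O)c2c1` — 550 nM in an assay on isolated protein for inhibition of fatty acid synthase (Rattus norvegicus); a higher number here means a weaker inhibitor, a lower number a stronger inhibitor
- compound 2, `N#Cc1ccc2nc(O)c(-c3ccccc3)c(O)c2c1` — "not determined" (no result reported) in this assay

Within the data shown here, compound 1 is the only member of the series with a number in this assay; compound 2 returned no result, so there is no second value to rank compound 1 against and no step between measured compounds from which to calibrate the effect of any change.

Compound 3, `O=[N+]([O-])c1cc2c(O)c(-c3ccccc3)c(O)nc2cc1F`, is the next compound to be measured in this assay. It differs from compound 1 by fluoro in place of hydrogen on an aromatic carbon. Nothing leaves but a hydrogen atom and a single fluorine enters, with no ring, no donors, no acceptors and no charge. Among the measured compounds shown here, with no measured step to lean on, the expected step from compound 1 to compound 3 is small, a 1.2-fold lower number from compound 1 to compound 3 (0.09 log units; within the scatter), and not clearly beyond the usual scatter in either direction. The estimate for compound 3 in this assay is therefore 450 nM, expected to fall between 150 nM and 1500 nM.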

Compound 3, half-maximal inhibitory concentration: 50 nM
Beside the measured number, compound 3's estimate is 9.0-fold (0.95 log units) above it; measured number below the stated range.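

In this assay, among these compounds, the aromatic carbon ortho to a nitro group turns out to be sensitive to even the smallest substitution: fluoro in place of hydrogen gives an 11-fold lower number from compound 1 to compound 3 (1.04 log units; beyond the scatter) and provides the first step against which other changes can be calibrated. The entering group is a single fluorine atom, with no ring, no hydrogen-bond donors or acceptors and no net charge, so this position on the core of compound 1 cannot be treated as a silent site where small changes leave the number in place. Nothing at hand bears on what lies behind a step of this size, and the result stands as an observation only.

Open, as far as these compounds go, is whether a chlorine atom, a methyl group or an amine at this same position would give a step of similar size, or whether the step is particular to fluoro. Equally open, from the compounds shown here alone, is whether the step carries over to a core with a nitrile in place of the nitro group, as in compound 2, which returned no result.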